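Swapping a Halogenated Phenyl for an Ethynylphenyl

The source may report more compounds than this note shows. Statements on the series, on what has been measured and on what is new or still open speak of the compounds shown alone.

In a functional assay on A549 cells (Homo sapiens) for antiproliferative activity, read by MTT assay, with a stated time of 48 h (on this read-out lower numbers stand for stronger inhibition and higher numbers for weaker inhibition), compound 1 (`O=C(/C=C/c1ccccc1)Nc1cc2c(Nc3ccc(F)c(Cl)c3)ncnc2s1`) gives 11200 nM as one of only three measured results so far. Compound 2 (`O=C(/C=C/c1ccccc1)Nc1cc2ncnc(Nc3ccc(F)c(Cl)c3)c2s1`) gives 6670 nM and compound 3 (`COc1ccc(/C=C/C(=O)Nc2cc3c(Nc4cc(Cl)cc(Cl)c4)ncnc3s2)cc1`) gives 21900 nM in this assay as well. The number for compound 1 lies within the usual scatter of each of the other two, so it cannot be told apart from either of them.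

The unmeasured compound 4 (`C#Cc1cccc(Nc2ncnc3sc(NC(=O)/C=C/c4ccccc4)cc23)c1`) keeps the rest of compound 1 and changes one group. It carries 3-ethynylphenyl in place of 3-chloro-4-fluorophenyl on a nitrogen on an aromatic ring.

Within the data shown here, no measured pair of compounds isolates this swap, so the data give no direct size for it. With compound 1 at 11200 nM as the closest reference, no step beyond the scatter is expected in this assay in either direction. The estimated step of a 1.1-fold higher number from compound 1 to compound 4 (0.03 log units; within the scatter) is therefore expected to be small. For compound 4 the estimated value is 12000 nM (expected range 5000 nM to 29000 nM).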

Compound 4, half-maximal inhibitory concentration: 10100 nM
The estimate for compound 4 lay 1.2-fold (0.07 log units) above the measured number; low and high end bracket the measured number.
By their numbers in this assay, from the lowest: compounds 2, 4, 1 and 3 (each within the scatter of the next, the first and the last beyond it).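

In this assay, putting 3-ethynylphenyl in place of 3-chloro-4-fluorophenyl gives a 1.1-fold lower number from compound 1 to compound 4 (0.04 log units; within the scatter). Among these compounds, this is the first pair here that differs in only one place, so it gives the first direct reading at this nitrogen on an aromatic ring: the two halogens can be replaced by an ethynyl group, with the heavy-atom count unchanged, without a shift that this assay can distinguish from ordinary scatter. Nothing available explains why the two groups read alike.

This single swap does not show whether the position tolerates change in general, so a plain phenyl, a 3-aminophenyl or a phenyl bearing a carboxylic acid on the same nitrogen might still move the number beyond the scatter. It also leaves open whether 3-ethynylphenyl would read the same way on the core of compound 2 or alongside the methoxy group of compound 3.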